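Vero cytotoxicity limits and a 2-phenylethenyl analogue

The source may hold more compounds than are shown below. What is called first, only, known or untested is meant among the compounds shown, and "the series" means these compounds.

Measured compounds:
compound 1 `O=C(c1ccncc1)N1N=C(c2cc3ccccc3o2)CC1c1cccc([N+](=O)[O-])c1`, in an ADME assay on Vero cells (Chlorocebus sabaeus) for cytotoxicity, read by MTT assay, with a stated time of 72 h (on this read-out higher numbers stand for weaker inhibition and lower numbers for stronger inhibition), compound 1 gives a limit of > 240000 nM.
compound 2 `COc1ccc(C2CC(c3cc4ccccc4o3)=NN2C(=O)c2ccncc2)c(O)c1`, in this assay compound 2 gives a limit of > 190000 nM.
compound 3 `O=C(c1ccncc1)N1N=C(c2cc3ccccc3o2)CC1c1ccccc1`, in this assay compound 3 gives a limit of > 209000 nM.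

Compound 2 sits at a limit, not a number, as do the other two values shown; the series therefore gives no ordering. The steps that touch compound 2 are a step that the two limits leave unreadable from compound 1 to compound 2 and a step that the two limits leave unreadable from compound 2 to compound 3, and the remaining step, a step that the two limits leave unreadable from compound 1 to compound 3, is of the same kind: each is unreadable because both ends are limits, as seen in the limit of > 190000 nM in this assay, at which 1 of the 3 values shown sits, the limit of > 209000 nM in this assay, at which 1 of the 3 values shown sits, and (the limit of > 240000 nM in this assay, at which 1 of the 3 values shown sits).

Compound 4 `O=C(c1ccncc1)N1N=C(c2cc3ccccc3o2)CC1/C=C/c1ccccc1` differs from compound 2 by 2-phenylethenyl in place of 2-hydroxy-4-methoxyphenyl on a saturated ring carbon. The step from compound 2 to compound 3 bears most directly on this change, since it also replaces the 2-hydroxy-4-methoxyphenyl group, but it is unreadable, so no step beyond the scatter can be expected in either direction in this assay. The step expected is a step that the limit leaves unreadable from compound 2 to compound 4. Compound 4 is expected to give about 250000 nM, within 100000 nM to 600000 nM, most likely again as a limit.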

Compound 4, half-maximal inhibitory concentration: > 212000 nM
Compound 4: only a limit was reported (the forecaster's own chance of this, stated with the estimate: 80%); the middle value does not contradict the limit.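

In this assay compound 4 gives > 212000 nM, a limit and not a number. Among the compounds shown here, with limits at both ends, no step from compound 1, compound 2 or compound 3 to compound 4 can be read. The compounds shown leave open where any of the four true values lies and whether the group on the saturated ring carbon changes them.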